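Non-cytotoxic amides: swapping the ring nitrogen substituent

The compounds below may be only part of what the source reports. "The series", "measured", "known", "first", "only" and "open" are said of these compounds alone.

Compound 1, `CCCCCN1C(=O)C/C(=C\c2cccc(C(=O)Nc3ccc(C)cc3)c2)C1=O`, in an ADME assay on NCM460 cells (Homo sapiens) for cytotoxicity, read by MTT assay, with a stated time of 72 h; a higher number here means a weaker inhibitor, a lower number a stronger inhibitor: > 100000 nM
Compound 2, `CCCCCN1C(=O)C/C(=C\c2cccc(C(=O)Nc3cccc(CC)c3)c2)C1=O`, in this assay: > 100000 nM
Compound 3, `COc1ccc(NC(=O)c2cccc(/C=C3\CC(=O)N(c4ccc(C)cc4)C3=O)c2)cc1`, in this assay: > 100000 nM

Each of these values is a limit of this assay, not a measured number. Compound 3 gives only the limit > 100000 nM, so where it stands can be said only as far as the limit of > 100000 nM in this assay, at which 3 of the 3 values shown sit, allows. The same is true of compound 1 with > 100000 nM and of compound 2 with > 100000 nM.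

Compound 4, `CCCCCN1C(=O)C/C(=C\c2cccc(C(=O)Nc3ccc(OC)cc3)c2)C1=O`, differs from compound 3 by pentyl in place of 4-methylphenyl on an amide-type nitrogen in a ring. Within the data shown here, the single measured step, a step that the two limits leave unreadable from compound 1 to compound 2, concerns the amide-type nitrogen and not the ring nitrogen, and its size cannot be read because both of its values are limits. Among the measured compounds shown here, no measured step therefore bears directly on this change. With every shown compound sitting at the limit, compound 4 is expected to behave in the same way, and the estimated step that the limit leaves unreadable from compound 3 to compound 4 is expected to be none beyond the scatter. Compound 4 is thus estimated at 150000 nM in this assay, within 70000 nM to 400000 nM, most likely reported again only as a limit.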

Compound 4, half-maximal inhibitory concentration: > 100000 nM
Compound 4: no number, only a limit; the forecaster's own chance of this, stated with the estimate: 85%; the middle value does not contradict the limit.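

Among these compounds, compound 4 also gives only a limit, so no step from compound 1, compound 2 or compound 3 to compound 4 can be read: the limit of > 100000 nM in this assay, at which 4 of the 4 values shown sit. The compounds shown leave open whether pentyl or 4-methylphenyl on the amide-type nitrogen in a ring makes any difference in this assay.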